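The source may hold more compounds than are shown below. What is called first, only, known or untested is meant among the compounds shown, and "the series" means these compounds.

Of the compounds shown here, three built on one shared core have been measured in a physicochemical assay for lipophilicity, at pH 7.4; a higher number here means a more lipophilic compound, a lower number a more polar compound. Compound 1 `Cc1nc(C)n(CC(=O)N2CCN(c3sc(C(F)(F)F)nc3-c3nc4ccc(C5CCOCC5)cc4[nH]3)C[C@H]2C)n1` gives 3.7. For the measured compounds named here, compound 3 `C[C@@H]1CN(c2sc(C(F)(F)F)nc2-c2nc3ccccc3[nH]2)CCN1C(=O)Cn1cnc2cccnc21` gives 3.9, a number within the scatter of the one for compound 1. Compound 2 `C[C@@H]1CN(c2sc(C(F)(F)F)nc2-c2nc3ccccc3[nH]2)CCN1C(=O)Cn1cnc2c1CCN(C)C2` gives 3, and compound 1 sits above it by a gap beyond the scatter. Going by the values given here, the only measured step with a change in a single place is a number 0.90 log units higher from compound 2 to compound 3 (beyond the scatter); the group that leaves compound 2 there is a six-membered non-aromatic ring holding a nitrogen that carries a methyl.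

Compound 4 `Cc1nc(C)n(CC(=O)N2CCN(c3sc(C(F)(F)F)nc3-c3nc4ccc(C5CCN(C)CC5)cc4[nH]3)C[C@H]2C)n1` has not yet been measured. It differs from compound 1 in one place: 1-methylpiperidin-4-yl in place of oxan-4-yl on an aromatic carbon. The entering 1-methylpiperidin-4-yl likewise holds a nitrogen carrying a methyl in a six-membered non-aromatic ring, the feature whose removal from compound 2 to compound 3 went with a climb in this assay. Among the compounds with values here, no measured step exchanges an oxygen-containing ring for such a group directly, so the comparison is loose. Still, a downward step beyond the scatter is expected. For compound 4 the value in this assay is estimated at 2.2, with a range from 1.5 to 2.9. That estimate means an expected a number 1.50 log units lower from compound 1 to compound 4 (beyond the scatter).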

Compound 4, distribution coefficient: 3.4
Compound 4: middle estimate off by 1.20 log units, on the low side, and the stated range ends below it.
By their numbers in this assay, from the lowest: compound 2; then compounds 4, 1 and 3 (each within the scatter of the next, the first and the last beyond it).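

At this place, an aromatic carbon of a six-membered aromatic ring of carbon only, 1-methylpiperidin-4-yl in place of oxan-4-yl goes with a number 0.30 log units lower from compound 1 to compound 4 (within the scatter) in this assay, so the two groups cannot be told apart here, although the entering group holds a nitrogen carrying a methyl where the leaving group holds an oxygen. The earlier step, a number 0.90 log units higher from compound 2 to compound 3 (beyond the scatter), lay beyond the scatter, but there a ring with such a nitrogen left from a saturated chain carbon bound to a carbonyl carbon and a different group entered, so that step does not carry over to this aromatic carbon. Nothing available here accounts for the difference between these two steps.

As far as these compounds go, what a piperidin-4-yl without the methyl, a longer chain ending in an amine, or a carboxylic acid would give on this same aromatic carbon in this assay remains open. For the compounds shown here, also open is whether 1-methylpiperidin-4-yl in place of oxan-4-yl would again stay within the scatter with a group other than the one compound 1 and compound 4 share on their saturated chain carbon.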